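The compounds below may be only part of what the source reports. "The series", "measured", "known", "first", "only" and "open" are said of these compounds alone.

Three close relatives of one shared core have been tested in an assay on membranes from HeLa cells for displacement of a labelled ligand from adenosine receptor A3 (Homo sapiens), read by scintillation counting, with a stated time of 180 min, tested at 1 uM; a lower number here means less inhibition, a higher number more inhibition at the concentration tested (going by the name of the read-out). Compound 1 `CC1=C(C(=O)OC2CCC2)C(c2ccco2)NC(=O)N1` gives 1%. Compound 2 `CC1=C(C(=O)OC2CCCC2)C(c2ccco2)NC(=O)N1` carries cyclopentyl in place of cyclobutyl on an oxygen next to a carbonyl group, and compound 2 gives 14%, so that the step is a number 13 percentage points higher from compound 1 to compound 2 (beyond the scatter). Compound 3 `CC1=C(C(=O)OC2CCC2)C(c2ccoc2)NC(=O)N1` keeps the ester of compound 1 but differs in the core by furan-3-yl in place of furan-2-yl on a saturated ring carbon; compound 3 gives 1%, a step of no change at the digits printed from compound 1 to compound 3 (within the scatter), which leaves compound 3 and compound 1 level at the digits shown, together the lowest of the three readings.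

Compound 4 `CC1=C(C(=O)OC2CCCC2)C(c2ccoc2)NC(=O)N1` has not yet been measured. It differs from compound 3 by cyclopentyl in place of cyclobutyl on an oxygen next to a carbonyl group, and this is the same change, at the same place, as the one that turned compound 1 into compound 2; it occurs twice among these four compounds. The only guide to its effect is the step of a number 13 percentage points higher from compound 1 to compound 2 (beyond the scatter), and the change of core did nothing at the digits shown, so a step of about that size is expected here, namely a number 11 percentage points higher from compound 3 to compound 4 (beyond the scatter). Compound 4 is therefore estimated to give 12%, expected to fall between 0% and 28%.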

Compound 4, a percentage reported as inhibition, at one concentration (the size of the read-out at that concentration, not a potency): 1%
Beside the measured number, compound 4's estimate is 11 percentage points above it, within the range that was stated.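

In this assay, putting cyclopentyl in place of cyclobutyl with furan-3-yl on the core gives no change at the digits printed from compound 3 to compound 4 (within the scatter), and moving from furan-2-yl to furan-3-yl with the cyclopentyl ester gives a number 13 percentage points lower from compound 2 to compound 4 (beyond the scatter). At first sight, the rise seen with furan-2-yl does not appear with furan-3-yl, but the two cyclopentyl steps cannot be told apart: the same change on two cores in this assay, a number 13 percentage points higher (beyond the scatter) from compound 1 to compound 2 and no change at the digits printed (within the scatter) from compound 3 to compound 4, 13 percentage points apart, within the scatter of two such steps. The same holds for the two furan steps, so these four compounds neither show that the cyclopentyl change carries over from one core to the other nor show that it fails to: the same change on two cores in this assay, no change at the digits printed (within the scatter) from compound 1 to compound 3 and a number 13 percentage points lower (beyond the scatter) from compound 2 to compound 4, 13 percentage points apart, within the scatter of two such steps.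

Each reading comes from a single concentration, so the compounds give no potencies, and repeat measurements would be needed to settle whether compound 2 truly stands apart from compound 4. As far as these compounds go, it also remains open how a larger ring such as cyclohexyl, or a longer chain such as n-hexyl, on the same oxygen would read with either furan.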